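Fluoro in place of hydroxy on a saturated side chain

The source may hold more compounds than are shown below. What is called first, only, known or untested is meant among the compounds shown, and "the series" means these compounds.

Compound 1 `Cn1c(-c2ccccc2C(F)(F)F)nnc1C12CCC(CCS(=O)(=O)C(C)(C)C)(CC1)CC2` was tested in an assay on CHO-K1 cells for inhibition of 11-beta-hydroxysteroid dehydrogenase type 2 (Homo sapiens), read by scintillation proximity assay; on this read-out higher numbers stand for weaker inhibition and lower numbers for stronger inhibition. In this assay compound 1 gives > 4000 nM, which is a limit of the assay rather than a number. Compound 2 `CC(O)CCCC12CCC(c3nnc(-c4ccccc4C(F)(F)F)n3C)(CC1)CC2` carries a 2-hydroxypropyl in place of the (tert-butyl)sulfonyl on a saturated chain carbon, two bonds along the chain from a saturated ring carbon. In this assay compound 2 gives > 1000 nM, again a limit of the assay and not a number. The step that the two limits leave unreadable from compound 1 to compound 2 therefore cannot be read. Compound 2 thus stands only at a limit, as the limit of > 1000 nM in this assay, at which 1 of the 2 values shown sits, shows, and the other value shown sits at the limit of > 4000 nM in this assay, at which 1 of the 2 values shown sits. Compound 3 `CC(F)CCCC12CCC(c3nnc(-c4ccccc4C(F)(F)F)n3C)(CC1)CC2` is not yet measured; it differs from compound 2 by fluoro in place of hydroxy on a saturated chain carbon bound to two saturated chain carbons. Within the data shown here, the only measured step that reaches compound 2 is unreadable, so no measured step gives a direction or a size for this change. Compound 3 is therefore expected to remain weak in this assay, most likely again at a limit, with an estimate of 3000 nM and a range from 800 nM to 20000 nM. The step that the limit leaves unreadable from compound 2 to compound 3 that this estimate means is expected to stay within the scatter.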

Compound 3, half-maximal inhibitory concentration: 1300 nM
The estimate for compound 3 lay 2.3-fold (0.36 log units) above the measured number, and the stated range covers the measured number.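

Among these compounds, compound 3 gives the first true number in this assay, at 1300 nM, so a side chain of this kind can now be placed on the scale rather than only at its edge. Set against the (tert-butyl)sulfonyl side chain, the 2-fluoropropyl group gives an at least 3.0-fold lower number from compound 1 to compound 3 (0.48 log units; beyond the scatter), which means that the identity of the side chain on this saturated ring carbon does register in the read-out. The two steps that involve compound 2, including the change from hydroxy to fluoro, cannot be read, because compound 2 has only a limit and its true value could lie close to that of compound 3 or far from it: the limit of > 1000 nM in this assay, at which 1 of the 3 values shown sits.

The compounds shown therefore leave open whether fluoro on this saturated chain carbon truly differs from hydroxy, and whether fluoro matters at all compared with a plain propyl chain carrying only hydrogen at that carbon. From the compounds shown here alone, it also remains open how an amine or a methoxy at the same carbon, or a longer chain carrying the fluoro, would read in this assay.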